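From compound 2 to compound 3: one group exchanged

A few compounds are considered here, and "the series" means these few. Any claim that something is new, unique, unknown or untested is made for them only; others in the source may bear on it.

In an ADME assay on microsomes from liver (Mus musculus) for metabolic stability, read by LC-MS, with a stated time of 1 h, tested at 5 uM (on this read-out higher numbers stand for a more stable compound and lower numbers for a less stable compound), compound 1 `CCC[C@H](Nc1nc(-c2ccc(NC(=O)NCC)c(OC)c2)ncc1C)c1cccnc1` gives 87.5% while compound 2 `Cc1cc(C)cc(N2CCN(C(=O)c3oc(C)nc3-c3ccccc3)CC2)c1` gives 12% and so stands lowest of the two, with a gap well beyond the usual scatter of repeated measurements. For the measured compounds named here, these two compounds differ in more than one place, so their gap says nothing about any single change, and no measured step can guide the next prediction.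

Compound 3 `Cc1nc(-c2ccccc2)c(C(=O)N2CCN(c3cccc(C#N)c3)CC2)o1` differs from compound 2 in one place only, with 3-cyanophenyl in place of 3,5-dimethylphenyl on an amine nitrogen in a ring. Whether this exchange helps has not been measured. A rise looks likelier than a fall because compound 2 at 12% has little room left to drop. The expected direction is therefore upward, with an estimated step of a number 18 percentage points higher from compound 2 to compound 3 (beyond the scatter) in this assay and only modest confidence in its size. For compound 3 the estimated value is 30% with an expected range from 12% to 55% in repeated measurements.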

Compound 3, percent of the compound remaining: 1.6%
Compound 3: the middle estimate sits 28.4 percentage points above what was measured; measured number outside the range, below it.
By their numbers in this assay, from the lowest: compound 3; then compound 2; then compound 1.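

For the compounds shown here, exchanging 3,5-dimethylphenyl for 3-cyanophenyl on an amine nitrogen in a ring gives the first comparison in this assay in which only one place changes, and it reads as a step of a number 10.4 percentage points lower from compound 2 to compound 3 (beyond the scatter). This shows that the group at this position can move the number even in a compound that already stands low, so compound 2 had not reached a floor. Both groups hold 8 heavy atoms and one six-membered aromatic ring of carbon only, so the step comes with a swap of what that ring carries, a nitrile with its triple bond and hydrogen-bond acceptor for the methyl groups, and no measurement shown explains why the number moved.

This single pair cannot separate the arrival of the nitrile from the departure of the methyl groups, and it cannot show whether the same exchange would act alike on another core. Also open, on these data alone, is how an unsubstituted phenyl, a 3-fluorophenyl or a cyclohexyl group would stand on the same nitrogen.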